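The compounds below may be only part of what the source reports. "The series", "measured", "known", "first", "only" and "open" are said of these compounds alone.

Measured compounds in an ADME assay on MCF-10A cells (Homo sapiens) for cytotoxicity, read by sulforhodamine B assay, with a stated time of 48 h; a lower number here means a stronger inhibitor of growth, a higher number a weaker inhibitor of growth:
compound 1 `NC(=S)N/N=C1/C(=O)N(CN2CCN(c3ccnc4cc(C(F)(F)F)ccc34)CC2)c2cc(Cl)ccc21` gives 38800 nM
compound 2 `NC(=S)N/N=C1/C(=O)N(CN2CCN(c3ccnc4cc(C(F)(F)F)ccc34)CC2)c2cc(Br)ccc21` gives 27000 nM
compound 3 `NC(=S)N/N=C1\C(=O)Nc2cccc(Cl)c21` gives 28700 nM

The one counted step among these is bromo in place of chloro on an aromatic carbon, which gives a 1.4-fold lower number from compound 1 to compound 2 (0.16 log units; within the scatter). Compound 3 and compound 1 share no single counted difference; the difference between the two cores is not broken down here. Compound 3 and compound 2 sit within the scatter of each other.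

Compound 4 `NC(=S)N/N=C1\C(=O)Nc2cccc(Br)c21` is not yet measured. It differs from compound 3 by bromo in place of chloro on an aromatic carbon. This is the same kind of change as that from compound 1 to compound 2, not the same: in compound 4 the site is ortho to a fused ring and meta to a fused ring, whereas in compound 2 it is meta to a fused ring and para to a fused ring. Because a 1.4-fold lower number from compound 1 to compound 2 (0.16 log units; within the scatter) lies within the scatter, the step of a 1.2-fold lower number from compound 3 to compound 4 (0.08 log units; within the scatter) is expected to be of the same small size. Compound 4 is expected to give 24000 nM in this assay, between 11000 nM and 50000 nM.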

Compound 4, concentration for 50% growth inhibition: 21400 nM
Compound 4: the middle estimate sits 1.1-fold (0.05 log units) above what was measured, and the stated range covers the measured number.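

In this assay, bromo in place of chloro on an aromatic carbon gives a 1.3-fold lower number from compound 3 to compound 4 (0.13 log units; within the scatter), and this step matches the earlier one on the other core: the same change on two cores in this assay, a 1.4-fold lower number (0.16 log units; within the scatter) from compound 1 to compound 2 and a 1.3-fold lower number (0.13 log units; within the scatter) from compound 3 to compound 4, 1.1-fold (0.03 log units) apart, within the scatter of two such steps. On these two cores, the change therefore carries over as a small step, even though its site on the aromatic ring differs between them. Neither step stands clear of the scatter, so the agreement shows only that both are small; it does not show a real gain from bromo, nor predict the size of the step on any third core.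

The compounds shown hold only chloro or bromo at these sites. As far as these compounds go, how an amine, a nitrile or a carboxylic acid would read there remains open.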